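Moving the chlorine on a compound at the limit

The compounds below may be only part of what the source reports. "The series", "measured", "known", "first", "only" and "open" are said of these compounds alone.

- compound 1 (`O=S(=O)(NCCNC(=S)Nc1cccc(Cl)c1)c1ccc(-c2ccccc2OCc2cccc(O)c2)s1`) gives 5800 nM
- compound 2 (`O=S(=O)(NCCNC(=S)Nc1cccc(Cl)c1)c1ccc(-c2ccccc2OCc2ccccc2)s1`) gives > 50000 nM
- compound 3 (`Cc1ccc(-c2ccsc2S(=O)(=O)NCCNC(=S)Nc2ccc([N+](=O)[O-])cc2)c(Oc2ccc(O)c(O)c2)c1`) gives 5100 nM

All three readings come from a functional assay on RS4-11 cells (Homo sapiens) for inhibition, read by CCK-8 assay, with a stated time of 48 h (a lower number here means a stronger inhibitor, a higher number a weaker inhibitor), and describe how strongly each compound inhibits these cells. Compound 2 gives > 50000 nM as a limit of the assay and not as a number.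

Compound 4 (`O=S(=O)(NCCNC(=S)Nc1ccc(Cl)cc1)c1ccc(-c2ccccc2OCc2ccccc2)s1`) has the same atoms as compound 2 but joined differently (4-chlorophenyl in place of 3-chlorophenyl on an amide-type nitrogen). In words, 4-chlorophenyl stands in place of 3-chlorophenyl on an amide-type nitrogen.

Within the data shown here, only one measured step is available for comparison. Since an at least 8.6-fold higher number from compound 1 to compound 2 (0.93 log units; beyond the scatter) comes from hydrogen in place of hydroxy on an aromatic carbon and not from moving the chlorine, it gives no size for this change. Compound 3 at 5100 nM differs from compound 2 in several places and offers no clean comparison. No step beyond the scatter is therefore expected in this assay for this move, and no direction can be favoured. The expected change (an at least 1.1-fold lower number from compound 2 to compound 4 (0.04 log units; that floor lies within the scatter)) is an estimate with wide uncertainty. For compound 4 the estimated value is 45000 nM with an expected range from 15000 nM to 100000 nM and a good chance of another limit.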

Compound 4, half-maximal inhibitory concentration: > 50000 nM
Compound 4 ended at the assay's limit; the forecaster's own chance of this, stated with the estimate: 60%; middle value at least 1.1-fold (0.04 log units) from the limit.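

Compound 2 and compound 4 both end at a limit rather than at a number, so the move from 3-chlorophenyl to 4-chlorophenyl gives no readable step: the limit of > 50000 nM in this assay, at which 2 of the 4 values shown sit.

The compounds shown leave open whether the two chlorine placements differ at all, and whether they would differ in compounds carrying the hydroxy of compound 1.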